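The source may report more compounds than this note shows. Statements on the series, on what has been measured and on what is new or still open speak of the compounds shown alone.

Measured so far:
Compound 1, `CNc1nc(NC2(C#N)CCCCC2)nc(-n2ccnc2)n1`, gives 1050 nM in an in vitro assay on Sf21 cells for inhibition of high affinity 3',5'-cyclic-AMP phosphodiesterase 7A (Homo sapiens); a higher number here means a weaker inhibitor, a lower number a stronger inhibitor.
Compound 2, `CNc1nc(NC2(C#N)CCCCC2)nc(-n2cnc(C)n2)n1`, gives > 5000 nM in this assay; this value is a limit of the assay, not a number.

Compound 2 thus stands at the weaker end of the two values, sitting at the limit of > 5000 nM in this assay, at which 1 of the 2 values shown sits. Going by the values given here, the only measured step, an at least 4.7-fold higher number from compound 1 to compound 2 (0.67 log units; beyond the scatter), went in the weakening direction. Compound 3, `CNc1nc(NC)nc(NC2(C#N)CCCCC2)n1`, differs from compound 2 by methylamino in place of 3-methyl-1H-1,2,4-triazol-1-yl on an aromatic carbon. Among the compounds with values here, no measured step covers this exchange of a five-membered aromatic ring for an open-chain group, so the size and direction of the change in this assay remain open; the one measured step shows only that changes at this carbon can matter. The estimate for compound 3 is 5000 nM, with a range from 1000 nM to 30000 nM. This estimate implies an expected step of a number no higher from compound 2 to compound 3 (the limit leaves the size open), with a fair chance that the assay again reports only a limit.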

Compound 3, half-maximal inhibitory concentration: > 1000 nM
Compound 3: only a limit was reported; the forecaster's own chance of this, stated with the estimate: 50%; the middle value lies beyond the limit too.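

In this assay compound 3 gives only a limit, > 1000 nM, so its steps from compound 1 and from compound 2 cannot be read. The compounds shown leave open whether methylamino in place of 1H-imidazol-1-yl or 3-methyl-1H-1,2,4-triazol-1-yl gives a stronger or weaker inhibitor.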